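The compounds below may be only part of what the source reports. "The series", "measured", "known", "first", "only" and "open" are said of these compounds alone.

Measured compounds:
Compound 1 `COc1ccc(F)c(-c2ccc(COc3cccc([C@@H](CC(=O)O)C4CC4)c3)nc2CC(C)(C)C)c1` gives 150 nM in a functional assay on cells for agonist activity at Free fatty acid receptor 1 (Homo sapiens), read by FLIPR and calcium flux, with a stated time of 60 min; on this read-out higher numbers stand for an effect only at larger amounts of compound and lower numbers for an effect already at smaller amounts.
Compound 2 `COc1ccc(CCCC(C)(C)C)c(-c2ccc(COc3cccc(C(CC(=O)O)C4CC4)c3)cc2)c1` gives 410 nM in this assay.
Compound 3 `COc1ccc(CCCC(C)(C)C)c(N2CCC(COc3cccc(C(CC(=O)O)C4CC4)c3)CC2)c1` gives 11 nM in this assay.

Among these three, compound 3 has the lowest number, and both gaps are beyond the scatter: compound 1 sits closer to it, compound 2 furthest away. Compound 4 `COc1ccc(F)c(N2CCC(COc3cccc(C(CC(=O)O)C4CC4)c3)CC2)c1` has not yet been tested. It is built from compound 3 by one change, (fluoro in place of 4,4-dimethylpentyl on an aromatic carbon). Within the data shown here, no pair of measured compounds differs by exactly this exchange, so there is no measured step to lean on. The expectation is a loss: compound 1, which also carries a fluoro on its aromatic ring, gives 150 nM, and compound 2, which keeps the 4,4-dimethylpentyl chain but on a different core, gives 410 nM, both well above compound 3. Compound 4 is therefore estimated at 80 nM, within a range of 20 nM to 400 nM in this assay; this estimate means an expected step of a 7.3-fold higher number from compound 3 to compound 4 (0.86 log units; beyond the scatter).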

Compound 4, half-maximal effective concentration: 670 nM
Compound 4: the middle estimate sits 8.4-fold (0.92 log units) below what was measured; the whole stated range lies below it.
By their numbers in this assay, from the lowest: compound 3; then compound 1; then compounds 2 and 4 (each within the scatter of the next).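

On the aromatic carbon para to a methoxy group, putting fluoro in place of 4,4-dimethylpentyl gives a 61-fold higher number from compound 3 to compound 4 (1.78 log units; beyond the scatter) in this assay, a large step. Among these compounds, the earlier compounds differed from one another in more than one place, so this is the first direct reading of this position, and with everything else held the same, the group there clearly matters a great deal to the number. No measurement at hand bears on why the step is this large.

Among the compounds shown here, only two groups have been compared at this position, so it remains open whether a shorter chain such as n-propyl, or a cyclohexyl ring, would give a number nearer to that of compound 3 or of compound 4. From the compounds shown here alone, it is also open whether the same exchange would give a step of similar size on a different core.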